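Swapping the para substituent on a weakly active urea

The source may hold more compounds than are shown below. What is called first, only, known or untested is meant among the compounds shown, and "the series" means these compounds.

Compound 1 `COc1cc2ncnc(NCc3cccc(NC(=O)Nc4ccccc4C)c3)c2cc1OC` is read in a functional assay on MGC-803 cells (Homo sapiens) for antiproliferative activity, read by MTT assay (a higher number here means a weaker inhibitor, a lower number a stronger inhibitor), only as a limit, > 50000 nM. Within the data shown here, compound 2 `COc1cc2ncnc(NCc3cccc(NC(=O)Nc4ccc(Cl)cc4)c3)c2cc1OC` gives 44200 nM, the one actual number in the set. The step of an at least 1.1-fold lower number from compound 1 to compound 2 (0.05 log units; that floor lies within the scatter) sits within the scatter. Compound 3 `COc1cc2ncnc(NCc3cccc(NC(=O)Nc4ccc([N+](=O)[O-])cc4)c3)c2cc1OC` carries the change (nitro in place of chloro on an aromatic carbon). Among the measured compounds shown here, the only measured step that bears on it also altered this same phenyl ring and moved the number no more than noise allows, so no step beyond the scatter is expected. Compound 3 is expected near 40000 nM, between 15000 nM and 120000 nM, which is an expected step of a 1.1-fold lower number from compound 2 to compound 3 (0.04 log units; within the scatter).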

Compound 3, half-maximal inhibitory concentration: 8120 nM
Estimate against measurement, compound 3: 4.9-fold (0.69 log units) above; the measured number lies below the stated range.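

In this assay, among these compounds, nitro in place of chloro gives a 5.4-fold lower number from compound 2 to compound 3 (0.74 log units; beyond the scatter), the first step in this set to clear the scatter, so the group at this spot on the phenyl ring does matter. The other step, an at least 6.1-fold lower number from compound 1 to compound 3 (0.78 log units; beyond the scatter), also lies beyond the scatter but is only a floor, as one end of it is a limit of the assay: the limit of > 50000 nM in this assay, at which 1 of the 3 values shown sits.

On these data alone, whether this gain is particular to nitro stays open. An amine, a nitrile or a methoxy group on the same carbon would show how other groups move the number.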